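The compounds below may be only part of what the source reports. "The series", "measured", "known", "first", "only" and "open" are said of these compounds alone.

Compound 1 `Cc1ccc(NC(=O)C(F)(F)F)cc1S(=O)(=O)N(C)/N=C/c1cnn2ccc(C#N)cc12` carries a trifluoromethyl on the amide carbonyl of the anilide that sits on the sulfonamide-bearing ring of the shared core. In an assay on isolated protein for inhibition of phosphatidylinositol 4,5-bisphosphate 3-kinase catalytic subunit beta isoform (Homo sapiens), read by 33P incorporation, with a stated time of 60 min (on this read-out lower numbers stand for stronger inhibition and higher numbers for weaker inhibition), compound 1 gives > 1000 nM, which is a limit of the assay and not a number. Compound 2 `Cc1ccc([N+](=O)[O-])cc1S(=O)(=O)N(Cc1ccccc1)/N=C/c1cnn2ccc(C#N)cc12` is the related analogue with a nitro group in place of the anilide and a benzyl on the sulfonamide nitrogen. In this assay compound 2 likewise gives > 1000 nM, again only a limit. Going by the values given here, compound 1 therefore stands nowhere that can be ranked: both values shown sit at the limit of > 1000 nM in this assay, at which 2 of the 2 values shown sit, so no measured step between them exists and no direction can be read from the pair.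

Compound 3 `CC(=O)Nc1ccc(C)c(S(=O)(=O)N(C)/N=C/c2cnn3ccc(C#N)cc23)c1` is the acetamido analogue of compound 1. The change is methyl in place of trifluoromethyl on a carbonyl carbon. Nothing measured here shows how this part of the molecule affects inhibition, so the expected step from compound 1 to compound 3 is none beyond the scatter, written as a step that the limit leaves unreadable from compound 1 to compound 3. Compound 3 is accordingly expected to give about 3000 nM in this assay, within a range of 800 nM to 15000 nM, and most likely to be reported only as a limit as well.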

Compound 3, half-maximal inhibitory concentration: > 1000 nM
Compound 3 ended at the assay's limit; the forecaster's own chance of this, stated with the estimate: 80%; the middle value lies beyond the limit too.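

In this assay compound 3 gives > 1000 nM, which is a limit of the assay and not a number. Compound 1 also stands at a limit, so no step between compound 1 and compound 3 can be read: the limit of > 1000 nM in this assay, at which 3 of the 3 values shown sit.

The compounds shown leave open whether methyl or trifluoromethyl on the carbonyl carbon makes any difference to inhibition.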